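The source may report more compounds than this note shows. Statements on the series, on what has been measured and on what is new or still open speak of the compounds shown alone.

Going by the values given here, compound 1 `CCOC(=O)/C=C1/C(=O)Nc2ccccc21` gives 4830 nM in a functional assay on HL-60 cells (Homo sapiens) for cytotoxicity, read by CCK-8 assay, with a stated time of 72 h (a higher number here means a weaker inhibitor, a lower number a stronger inhibitor), the second highest of the three numbers measured so far; compound 2 `CC(C)(C)OC(=O)/C=C1/C(=O)Nc2ccccc21` gives 2450 nM, and compound 3 `CC(C)(C)OC(=O)/C=C1/C(=O)N(Cc2ccccc2)c2ccccc21` gives 13800 nM. The step of a 2.0-fold lower number from compound 1 to compound 2 (0.29 log units; within the scatter) stays within the scatter, whereas a 5.6-fold higher number from compound 2 to compound 3 (0.75 log units; beyond the scatter) lies beyond it. Compound 4 `CCOC(=O)/C=C1\C(=O)Nc2ccccc21` differs from compound 1 in this way: the two compounds have the same atoms and bonds and differ only in configuration as drawn: 1 of 1 stereo elements differ; a double bond is drawn E in compound 1 and Z in compound 4. Neither measured step touches configuration: one exchanges tert-butyl for ethyl on the oxygen, the other puts benzyl on the amide-type nitrogen in the ring, so nothing measured bears on this change. Compound 4 is therefore expected to show a step of no clear direction, a 1.0-fold lower number from compound 1 to compound 4 (0.00 log units; within the scatter). Compound 4 is estimated at 4800 nM in this assay, with a range from 1500 nM to 15000 nM.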

Compound 4, half-maximal inhibitory concentration: > 100000 nM
Compound 4: no number, only a limit; the forecaster's own chance of this, stated with the estimate: 5%; at least 20-fold (1.31 log units) between middle value and limit.
By their numbers in this assay, from the lowest: compounds 2 and 1 (each within the scatter of the next); then compound 3. At a limit, above all of these: compound 4.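

Going by these compounds alone, the configuration of the double bond, which no earlier compound varied, carries a large step in this assay: an at least 20-fold higher number from compound 1 to compound 4 (1.31 log units; beyond the scatter). Compound 4 gives > 100000 nM, which is a limit of the assay and not a number. The step can be set on configuration alone: the fact that compounds 1 and 4 differ only in the configuration as drawn

On these data alone, whether the Z drawing has the same effect with tert-butyl on the oxygen, or with benzyl on the amide-type nitrogen in the ring, remains open. Also open, as far as these compounds go, is how either drawing behaves with a longer chain or an amine in place of ethyl.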